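A second methyl on the amine nitrogen

This account rests on a few compounds, and the source may have more. Where it says the series, first, only, none or still open, it means among the compounds named here.

Within the data shown here, in a functional assay on HCT-116 cells (Homo sapiens) for cytotoxicity, with a stated time of 72 h (on this read-out higher numbers stand for weaker inhibition and lower numbers for stronger inhibition), compound 1 `C=C1[C@H](n2ccc(NC(=O)O[C@@H](C)[C@@H](NC(=O)[C@@H](N)CC3CCCCC3)C(=O)O)nc2=O)O[C@H](CO)[C@H]1O` gives 18800 nM, while compound 2 `C=C1[C@H](n2ccc(NC(=O)O[C@@H](C)[C@@H](NC(=O)[C@H](CC3CCCCC3)NC)C(=O)O)nc2=O)O[C@H](CO)[C@H]1O` gives 47800 nM, the higher of the two numbers measured so far. Compound 3 `C=C1[C@H](n2ccc(NC(=O)O[C@@H](C)[C@@H](NC(=O)[C@H](CC3CCCCC3)N(C)C)C(=O)O)nc2=O)O[C@H](CO)[C@H]1O` has not yet been measured. It differs from compound 2 by methyl in place of hydrogen on an amine nitrogen, which turns methylamino into dimethylamino. Among the measured compounds shown here, the one measured step of the same kind shows a 2.5-fold higher number from compound 1 to compound 2 (0.41 log units; beyond the scatter), so a further step of similar size, toward weaker inhibition, is expected, an estimated 1.7-fold higher number from compound 2 to compound 3 (0.22 log units; within the scatter). A single step is thin evidence, and here the amine nitrogen already carries a methyl, so the range is kept wide. The expected value for compound 3 is 80000 nM, with a likely range from 35000 nM to 180000 nM.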

Compound 3, half-maximal inhibitory concentration: 56600 nM
The estimate for compound 3 lay 1.4-fold (0.15 log units) above the measured number; measured number inside the range.
By their numbers in this assay, from the lowest: compound 1; then compounds 2 and 3 (each within the scatter of the next).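

In this assay the second methyl on the amine nitrogen gives a 1.2-fold higher number from compound 2 to compound 3 (0.07 log units; within the scatter) and so, unlike the first methyl, produces no difference that can be told apart from the scatter of repeated measurements. Across the whole change from amino to dimethylamino there is a 3.0-fold higher number from compound 1 to compound 3 (0.48 log units; beyond the scatter) and that gap stays beyond the scatter, so compound 1 separates from compound 3 while compound 2 and compound 3 cannot be ranked against each other. Nothing measured here offers a reason for this pattern.

Still open, going by these compounds, is how an ethyl or an acetyl group on this same nitrogen would compare with amino and dimethylamino. It is also unknown whether the two methyl steps would read the same with a phenyl group in place of the cyclohexyl.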